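Adding Chlorine to a Phenyl Ring in Paw Edema Tests

The source may report more compounds than this note shows. Statements on the series, on what has been measured and on what is new or still open speak of the compounds shown alone.

Compound 1 `N#Cc1c(-c2ccccc2)nc(SCC(=O)Nn2c(COc3ccc(Cl)cc3Cl)nc3ccccc3c2=O)[nH]c1=O` and compound 2 `N#Cc1c(-c2ccc(Cl)cc2)nc(SCC(=O)Nn2c(COc3ccc(Cl)cc3Cl)nc3ccccc3c2=O)[nH]c1=O` share one core, while compound 3 `N#Cc1c(Cl)nc(SCC(=O)Nn2c(COc3ccc(Cl)cc3Cl)nc3ccccc3c2=O)nc1-c1ccccc1` and compound 4 `N#Cc1c(Cl)nc(SCC(=O)Nn2c(COc3ccc(Cl)cc3Cl)nc3ccccc3c2=O)nc1-c1ccc(Cl)cc1` share another; the difference between the two cores is not broken down here. In a functional assay on the whole organism (strain albino) for inhibition, with Rattus norvegicus as the target, read by paw edema, with stated times of 1 h and 3 h, at a dose of 100 mg/kg by the oral route (a higher number here means a stronger effect of the compound at the dose given, a lower number a weaker effect), compound 1 gives 86%, and compound 2 gives 64.9%. The change between them is chloro in place of hydrogen on an aromatic carbon, and it made a number 21.1 percentage points lower from compound 1 to compound 2 (beyond the scatter). In this assay compound 3 gives 68.4%. Compound 4 differs from compound 3 by chloro in place of hydrogen on an aromatic carbon, the same change at the same place on the ring. Because the earlier change gave a number 21.1 percentage points lower from compound 1 to compound 2 (beyond the scatter), a weaker effect is expected for compound 4 as well, although any single measurement scatters. The expected step is a number 15.4 percentage points lower from compound 3 to compound 4 (beyond the scatter). Compound 4 is estimated at 53%, with a likely range from 38% to 68%.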

Compound 4, a percentage reported as inhibition, in the whole organism at one dose (the size of the read-out at that dose, not a potency): 68.4%
Compound 4: middle estimate off by 15.4 percentage points, on the low side, and the stated range ends below it.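

In this assay, replacing phenyl with 4-chlorophenyl on the core of compound 3 gave no change at the digits printed from compound 3 to compound 4 (within the scatter), so the drop seen on the core of compound 1 did not carry over. The same change therefore gave different results on the two cores: the same change on two cores in this assay, a number 21.1 percentage points lower (beyond the scatter) from compound 1 to compound 2 and no change at the digits printed (within the scatter) from compound 3 to compound 4, 21.1 percentage points apart, beyond the scatter of two such steps. This shows that a step measured on one core cannot simply be transferred to the other in this series, but two pairs do not show which part of the cores accounts for the difference or what would happen on a third core.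

Going by these compounds, whether a fluoro group or an amine at the same place on the ring would lower the effect on both cores, on one, or on neither remains open.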